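Working notes: 4-methoxyphenyl in place of isopropyl

This account rests on a few compounds, and the source may have more. Where it says the series, first, only, none or still open, it means among the compounds named here.

Values in a functional assay on DLD-1 cells (Homo sapiens) for antiproliferative activity, read by CellTiter-Glo, with a stated time of 72 h (on this read-out lower numbers stand for stronger inhibition and higher numbers for weaker inhibition), are as follows
- Compound 1 `CC1CCN(C2CCN(S(=O)(=O)c3ccc(-c4ccccc4)cc3)CC2)CC1` gives 258 nM
- Compound 2 `CCc1ccc(S(=O)(=O)N2CCC(N3CCC(C)CC3)CC2)cc1` gives > 5000 nM as a limit of the assay
- Compound 3 `CC1CCN(C2CCN(S(=O)(=O)c3ccc(C(C)C)cc3)CC2)CC1` gives 685 nM
- Compound 4 `COc1ccc(-c2ccc(S(=O)(=O)N3CCC(N4CCC(C)CC4)CC3)cc2)cc1` has not yet been measured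

Of the two values that are numbers, compound 3 at 685 nM is the higher, and compound 1 at 258 nM is its nearest neighbour. The change at hand puts 4-methoxyphenyl in place of isopropyl on an aromatic carbon of a six-membered aromatic ring of carbon only, para to a large group (4-methoxyphenyl in place of isopropyl on an aromatic carbon).

The closest measured step is a 2.7-fold higher number from compound 1 to compound 3 (0.42 log units; beyond the scatter) with isopropyl in place of phenyl. Among the compounds with values here, the step of an at least 19-fold higher number from compound 1 to compound 2 (1.28 log units; beyond the scatter) with ethyl in place of phenyl points the same way, and no measured compound goes against this. The step of an at least 7.2-fold lower number from compound 2 to compound 3 (0.86 log units; beyond the scatter) concerns only the two chains and says little here. The entering group also holds a six-membered aromatic ring of carbon only, so the expectation follows compound 1 at 258 nM rather than compound 3. In this assay the expected change is a 2.7-fold lower number from compound 3 to compound 4 (0.44 log units; beyond the scatter) and thus modest. Within the data shown here, no measured compound carries the 4-methoxyphenyl group, so the range stays wide. For compound 4 the estimate is 250 nM with an expected range from 80 nM to 800 nM in this series.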

Compound 4, half-maximal inhibitory concentration: 263 nM
Compound 4: the middle estimate sits 1.1-fold (0.02 log units) below what was measured, within the range that was stated.
By their numbers in this assay, from the lowest: compounds 1 and 4 (each within the scatter of the next); then compound 3. At a limit, above all of these: compound 2.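

In this assay, methoxy in place of hydrogen on an aromatic carbon gives a 1.0-fold higher number from compound 1 to compound 4 (0.01 log units; within the scatter), so on this evidence the methoxy group leaves the read-out unchanged on the ring it occupies, and a substituted aromatic ring is accepted at this position. The step with 4-methoxyphenyl in place of isopropyl, a 2.6-fold lower number from compound 3 to compound 4 (0.42 log units; beyond the scatter), extends the earlier phenyl result: among the four compounds, the two that carry a second six-membered aromatic ring, compound 1 and compound 4, both have lower numbers than the two with a chain, compound 2 and compound 3, and none goes against this. Against ethyl the step is an at least 19-fold lower number from compound 2 to compound 4 (1.27 log units; beyond the scatter), and the value of compound 2 is a limit: the limit of > 5000 nM in this assay, at which 1 of the 4 values shown sits.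

The compounds shown do not separate the aromatic ring from the larger size of the entering group, a distinction that a cyclohexyl group at this position would test. On these data alone, on the second aromatic ring, only hydrogen and methoxy can be compared, so the outcome with an amine or a carboxylic acid there remains open.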